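Replacing trifluoromethyl by hydroxymethyl: compound 3 to compound 4

The source may report more compounds than this note shows. Statements on the series, on what has been measured and on what is new or still open speak of the compounds shown alone.

Compound 1 `CCOC(=O)c1c(-c2cc(F)cc(OC)c2)[nH]c2cc(OC)ccc2c1=O`: > 21500 nM in an ADME assay on HepG2 cells (Homo sapiens) for cytotoxicity, read by luminescence, with a stated time of 72 h; on this read-out higher numbers stand for an effect only at larger amounts of compound and lower numbers for an effect already at smaller amounts
Compound 2 `CCOC(=O)c1c(-c2cccc(OCc3ccccc3)c2)[nH]c2cc(OC)ccc2c1=O`: > 21500 nM
Compound 3 `CCOC(=O)c1c(-c2cccc(C(F)(F)F)c2)[nH]c2cc(OC)ccc2c1=O`: > 21500 nM

Each of these three values is a limit of this assay rather than a number. Compound 3 therefore stands only at a limit, and so do the two other values shown. Within the data shown here, the single step between measured neighbours, a step that the two limits leave unreadable from compound 2 to compound 3, cannot be read for the same reason, as the limit of > 21500 nM in this assay, at which 3 of the 3 values shown sit, records.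

Compound 4 `CCOC(=O)c1c(-c2cccc(CO)c2)[nH]c2cc(OC)ccc2c1=O` differs from compound 3 by hydroxymethyl in place of trifluoromethyl on an aromatic carbon. Among the measured compounds shown here, no measured step speaks for or against this change. Since every value shown sits at the limit, compound 4 is expected to stay there too, giving an estimated 25000 nM (15000 nM to 60000 nM). The expected step is a step that the limit leaves unreadable from compound 3 to compound 4, which is no change beyond the scatter.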

Compound 4, half-maximal effective concentration: > 21500 nM
Compound 4 ended at the assay's limit; the forecaster's own chance of this, stated with the estimate: 85%; the middle value does not contradict the limit.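

Compound 4 sits at a limit of the assay, as do compound 1, compound 2 and compound 3, so no step between them can be read: the limit of > 21500 nM in this assay, at which 4 of the 4 values shown sit.

The compounds shown leave open whether their different groups change the result in this assay, and at what amount any of them would show an effect.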